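Swapping the benzyl aryl group on a pyrazole acid series

This account rests on a few compounds, and the source may have more. Where it says the series, first, only, none or still open, it means among the compounds named here.

Compound 1 `Cc1cc(C(=O)O)nn1Cc1cc(Br)ccc1OCc1ccc(Cl)cc1` gives 8.71 nM in an assay on CHO-K1 cells for displacement of a labelled ligand from prostaglandin E2 receptor EP1 subtype (Homo sapiens); a higher number here means a weaker inhibitor, a lower number a stronger inhibitor. Compound 2 `Cc1cc(C(=O)O)nn1Cc1cc(Br)ccc1OCc1ccccc1Cl` gives 3.16 nM in this assay. Compound 3 `Cc1cc(C(=O)O)nn1Cc1cc(Br)ccc1OCc1c(F)cccc1F` gives 14.8 nM in this assay.

Compound 3 stands highest of the three numbers: compound 1 is nearest, with a 1.7-fold higher number from compound 1 to compound 3 (0.23 log units; within the scatter) separating them, and compound 2 is furthest, with a 4.7-fold higher number from compound 2 to compound 3 (0.67 log units; beyond the scatter). Compound 4 `Cc1cccc(COc2ccc(Br)cc2Cn2nc(C(=O)O)cc2C)c1` is obtained by 3-methylphenyl in place of 2,6-difluorophenyl on a saturated chain carbon bound to an oxygen on an aromatic ring. Going by the values given here, no measured step involves 3-methylphenyl, so the only guide is that both single-substituted phenyl groups, in compound 1 and compound 2, gave lower numbers than compound 3 in this assay. A modest step lower is therefore expected, a 2.1-fold lower number from compound 3 to compound 4 (0.33 log units; beyond the scatter). Compound 4 is estimated at 7 nM, within 2.5 nM to 20 nM.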

Compound 4, half-maximal inhibitory concentration: 126 nM
Compound 4: middle estimate off by 18-fold (1.26 log units), on the low side; measured number outside the range, above it.
By their numbers in this assay, from the lowest: compound 2; then compounds 1 and 3 (each within the scatter of the next); then compound 4.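

In this assay, 3-methylphenyl on the saturated chain carbon bound to an oxygen on an aromatic ring gives the highest number of the four, with an 8.5-fold higher number from compound 3 to compound 4 (0.93 log units; beyond the scatter) and a 14-fold higher number from compound 1 to compound 4 (1.16 log units; beyond the scatter) and a 40-fold higher number from compound 2 to compound 4 (1.60 log units; beyond the scatter). So this position does not accept every substituted phenyl equally: the three rings carrying chlorine or fluorine all stay well below compound 4. Nothing available explains this gap. On these data alone, whether the rise follows the methyl group itself or its place on the ring stays open, and 3-chlorophenyl and 4-methylphenyl would separate the two.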